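Methyl on the carboxy group of compound 1

The source may report more compounds than this note shows. Statements on the series, on what has been measured and on what is new or still open speak of the compounds shown alone.

Values in a physicochemical assay for lipophilicity, at pH 7.4 (on this read-out higher numbers stand for higher lipophilicity and lower numbers for lower lipophilicity), are as follows.
- compound 1 `CCc1ccc(N(CC(C)C)S(=O)(=O)c2ccc3cc(OCC4CCOCC4)c(C(=O)O)cc3c2)cc1` gives 1.77
- compound 2 `CCc1ccc(N(CC2CC2)S(=O)(=O)c2ccc3c(c2)C(=O)CC(C2CCOCC2)O3)cc1` gives 3.77
- compound 3 `CCc1ccc(N(CC(C)C)S(=O)(=O)c2ccc3oc(C4CCOCC4)cc(=O)c3c2)cc1` gives 4.5

Compound 1 stands lowest of the three, beyond the scatter from both others. Compound 4 `CCc1ccc(N(CC(C)C)S(=O)(=O)c2ccc3cc(OCC4CCOCC4)c(C(=O)OC)cc3c2)cc1` has methyl in place of hydrogen on an oxygen next to a carbonyl group, which takes carboxy to methoxycarbonyl (methyl in place of hydrogen on an oxygen next to a carbonyl group). Among the measured compounds shown here, no measured pair differs in one place, so the size of the step remains a judgement. A large rise in this assay, beyond the scatter, is expected because compound 2 stands at 3.77 and compound 3 at 4.5 without the carboxy group. The expected step is a number 2.93 log units higher from compound 1 to compound 4 (beyond the scatter) in all. Compound 4 is estimated at 4.7 (range 4.1 to 5.3).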

Compound 4, distribution coefficient: 6.09
Estimate against measurement, compound 4: 1.39 log units below; the whole stated range lies below it.
By their numbers in this assay, from the lowest: compound 1; then compound 2; then compound 3; then compound 4.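

Carboxy to methoxycarbonyl gives the first comparison here that differs in one place, and in this assay the single added methyl produces a number 4.32 log units higher from compound 1 to compound 4 (beyond the scatter) as a large step. Compound 2 and compound 3 differ from compound 1 in more than one place, so they could not show that this one change, on an oxygen next to a carbonyl group, carries a step of this size. Nothing at hand gives a reason for it.

The compounds shown leave open whether a longer chain such as ethyl on this oxygen, or an amide in place of the ester, would move the number as far.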